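Pyridazin-3-yl to 3,5-difluoropyridin-2-yl on the shared core

The compounds below may be only part of what the source reports. "The series", "measured", "known", "first", "only" and "open" are said of these compounds alone.

Going by the values given here, in a physicochemical assay for solubility, using the shake flask method, measured as kinetic solubility, with a stated time of 20 h, at pH 2 (a lower number here means a less soluble compound, a higher number a more soluble compound), compound 2 `FC(F)(F)c1cccc(-c2nc3cnc(Nc4cccnn4)cc3[nH]2)c1` gives 161000 nM, the only actual number so far. Compound 1 `COc1ccnc(Nc2cc3[nH]c(-c4cccc(C(F)(F)F)c4)nc3cn2)c1` reads < 5000 nM, which is a limit of the assay and not a number. The change leading to compound 3 `Fc1cnc(Nc2cc3[nH]c(-c4cccc(C(F)(F)F)c4)nc3cn2)c(F)c1` is 3,5-difluoropyridin-2-yl in place of pyridazin-3-yl on a nitrogen on an aromatic ring. Among the compounds with values here, one measured step bears on it: an at least 32-fold higher number from compound 1 to compound 2 (1.50 log units; beyond the scatter), a large step beyond the scatter, with pyridazin-3-yl replacing 4-methoxypyridin-2-yl. The new change runs the other way, from pyridazin-3-yl back to a substituted pyridin-2-yl, so a large step to a lower number is expected in this assay. The estimated change is a 32-fold lower number from compound 2 to compound 3 (1.51 log units; beyond the scatter). For compound 3 the expected value is 5000 nM, with an estimated range of 1500 nM to 30000 nM.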

Compound 3, solubility: < 5000 nM
Compound 3: no number, only a limit; the forecaster's own chance of this, stated with the estimate: 60%; the middle value lies on the limit itself.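

In this assay, 3,5-difluoropyridin-2-yl in place of pyridazin-3-yl on a nitrogen on an aromatic ring gives an at least 32-fold lower number from compound 2 to compound 3 (1.50 log units; beyond the scatter), so the large gap to pyridazin-3-yl now holds against two different substituted pyridin-2-yl groups. Compound 3 gives < 5000 nM, which is a limit of the assay and not a number. The step between compound 1 and compound 3 cannot be read, and the two substituted pyridin-2-yl groups stay unordered: the limit of < 5000 nM in this assay, at which 2 of the 3 values shown sit.

Open, going by these compounds, is whether the high number belongs to pyridazin-3-yl alone, or is shared by an unsubstituted pyridin-2-yl or by a ring carrying an amine or a carboxylic acid at this place. Going by these compounds alone, with only one actual number, the size of any effect at this place relative to compound 2 also remains undefined.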